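The source may report more compounds than this note shows. Statements on the series, on what has been measured and on what is new or still open speak of the compounds shown alone.

Measured in an ADME assay on LLC-PK1 cells (Sus scrofa) for cytotoxicity, read by neutral red uptake; a lower number here means a stronger inhibitor, a higher number a weaker inhibitor:
- compound 1 `COC(/C=C/c1ccc(O)cc1)=C1\C(=O)C=C(C)C1=O`: 3.4 ug/mL
- compound 2 `COC(/C=C/c1cccs1)=C1\C(=O)C=C(C)C1=O`: 2.8 ug/mL

With only these two results in hand, compound 2 at 2.8 ug/mL has one neighbour, compound 1 at 3.4 ug/mL. The two values lie within the scatter of each other, so the numbers do not separate the compounds.

The next compound to be tested is compound 3 `COC(/C=C/c1ccco1)=C1\C(=O)C=C(C)C1=O`. It carries furan-2-yl in place of thiophen-2-yl on a double-bonded chain carbon bound to a double-bonded chain carbon. The counted difference is small, and the ring size and the net charge stay the same.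

Among the measured compounds shown here, no measured pair shows what this exchange does in this assay, so any forecast rests on little. For the measured compounds named here, the only guide is that the two known values sit close together, and no step beyond the scatter is expected in either direction. The expected change, a 1.1-fold higher number from compound 2 to compound 3 (0.03 log units; within the scatter), is an estimate that stays within that scatter. For compound 3 the estimated value is 3 ug/mL, with an expected range from 1.5 ug/mL to 6 ug/mL.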

Compound 3, half-maximal inhibitory concentration: 3.3 ug/mL
Beside the measured number, compound 3's estimate is 1.1-fold (0.04 log units) below it, and the stated range covers the measured number.
By their numbers in this assay, from the lowest: compounds 2, 3 and 1 (each within the scatter of the next).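

Among the compounds shown here, the exchange of thiophen-2-yl for furan-2-yl on a double-bonded chain carbon bound to a double-bonded chain carbon now has a measured result in this assay, and the step of a 1.2-fold higher number from compound 2 to compound 3 (0.07 log units; within the scatter) is the first direct reading of a single change at this place. The step lies within the scatter, so this assay does not separate the sulfur-containing ring from the oxygen-containing one, which have the same counted heavy atoms, donors, acceptors and net charge. No supporting measurement bears on this result, and the data give no explanation for how closely the two compounds read.

The compounds shown leave open whether any group at this place can move the number beyond the scatter, since only aromatic rings stand there; an amine, a carboxylic acid or a longer chain carbon group in place of the ring would test this. They also leave open whether the same exchange of thiophen-2-yl for furan-2-yl would read alike on a core carrying other groups.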